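The source may hold more compounds than are shown below. What is called first, only, known or untested is meant among the compounds shown, and "the series" means these compounds.

Compound 1 `COc1cc2nc(Nc3ccc(C#N)cc3)nc(Nc3c(C)cc(/C=C/C#N)cc3C)c2cc1OC`: 10200 nM.
Compound 2 `COc1cc2nc(Nc3ccc(C#N)cc3)nc(Nc3c(C)cc(/C=C/C#N)cc3F)c2cc1OC`: > 52000 nM, a limit of the assay.

Among the measured compounds shown here, in an ADME assay on MT4 cells (Homo sapiens) for cytotoxicity, read by MTT assay, with a stated time of 5 days (a lower number here means that less compound is tolerated, a higher number that more compound is tolerated), compound 1 gives 10200 nM, the only actual number so far. The reading for compound 2 is a limit (the limit of > 52000 nM in this assay, at which 1 of the 2 values shown sits). Compound 3 `COc1cc2nc(SCC(=O)Nc3ccc(F)cc3)nc(Nc3c(C)cc(/C=C/C#N)cc3C)c2cc1OC` differs from compound 1 at the aromatic carbon between two ring nitrogen atoms: a group of 12 heavy atoms (8 carbon, 1 nitrogen, 1 oxygen, 1 fluorine, 1 sulfur; one six-membered aromatic ring of carbon only) in place of a group of 9 heavy atoms (7 carbon, 2 nitrogen; one six-membered aromatic ring of carbon only), on an aromatic carbon. For the measured compounds named here, the one measured step, an at least 5.0-fold higher number from compound 1 to compound 2 (0.70 log units; beyond the scatter), is fluoro in place of methyl at another place, so it does not bear on this change. No step beyond the scatter is therefore expected, and the estimated step is a 1.2-fold higher number from compound 1 to compound 3 (0.07 log units; within the scatter). For compound 3 the expected value is 12000 nM, with an estimated range of 3500 nM to 40000 nM.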

Compound 3, half-maximal cytotoxic concentration: >= 150000 nM
Compound 3: a limit, no number; the forecaster's own chance of this, stated with the estimate: 25%; at least 12-fold (1.09 log units) between middle value and limit.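

At the aromatic carbon between two ring nitrogen atoms, the core proves sensitive in this assay: the new group in place of (4-cyanophenyl)amino gives an at least 14-fold higher number from compound 1 to compound 3 (1.16 log units; beyond the scatter). Fluoro in place of methyl had so far been the only change seen to move the number, and that lies at another place. The reading for compound 3 is a limit of the assay: the limit of >= 150000 nM in this assay, at which 1 of the 3 values shown sits.

The compounds shown do not separate the sulfur, the amide and the fluorine of the entering group. On these data alone, how a simple amine or a longer alkyl chain would read at this position remains open.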